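The compounds below may be only part of what the source reports. "The series", "measured", "known", "first", "only" and "open" are said of these compounds alone.

Compound 1 `c1ccc2c(c1)CCC2NC1CCN(CCCc2c[nH]c3ccc(-n4cnnc4)cc23)CC1` gives 8.9 nM in an assay on CHO cells for displacement of a labelled ligand from 5-hydroxytryptamine receptor 1D (Homo sapiens); a higher number here means a weaker inhibitor, a lower number a stronger inhibitor. Compound 2 `c1ccc(CNC2CCN(CCCc3c[nH]c4ccc(-n5cnnc5)cc34)CC2)cc1` gives 4.6 nM. Compound 3 `CC(=O)Nc1ccc([C@H](C)NCC2CCN(CCCc3c[nH]c4ccc(-n5cnnc5)cc34)CC2)cc1` gives 0.6 nM.

Compound 2 stands second highest of the three numbers in this assay; its nearest neighbour is compound 1, with a higher number that lies within the scatter, and its furthest is compound 3, with a lower number that lies beyond the scatter. Compound 4 `C[C@@H](NCC1CCN(CCCc2c[nH]c3ccc(-n4cnnc4)cc23)CC1)c1ccccc1` differs from compound 2 by ((1-phenylethyl)amino)methyl in place of benzylamino on a saturated ring carbon. Among the measured compounds shown here, only one measured step touches the same place, and it is small: a 1.9-fold lower number from compound 1 to compound 2 (0.29 log units; within the scatter), within the scatter, so swapping one aromatic amine substituent for another of similar size has not by itself moved the number. For the measured compounds named here, compound 4, however, carries the same methylene-linked 1-arylethylamine arrangement as compound 3, and compound 3 gives 0.6 nM, a clearly lower number than compound 2 shows; no single-point step connects compound 3 and compound 4, so their two values are only a hint. On that basis compound 4 is expected to show a step of a 3.1-fold lower number from compound 2 to compound 4 (0.49 log units; beyond the scatter), toward a lower number. The estimate for compound 4 in this assay is 1.5 nM, within the range 0.5 nM to 5 nM.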

Compound 4, half-maximal inhibitory concentration: 1.4 nM
For compound 4 the middle estimate is 1.1-fold (0.03 log units) above the measured one, within the range that was stated.
By their numbers in this assay, from the lowest: compound 3; then compound 4; then compounds 2 and 1 (each within the scatter of the next).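

In this assay, ((1-phenylethyl)amino)methyl in place of benzylamino on the saturated ring carbon gives a 3.3-fold lower number from compound 2 to compound 4 (0.52 log units; beyond the scatter), and in place of (2,3-dihydro-1H-inden-1-yl)amino it gives a 6.4-fold lower number from compound 1 to compound 4 (0.80 log units; beyond the scatter). Among the compounds shown here, this position therefore responds to a change beyond the scatter, which the one earlier step there, between two amine substituents, did not show. The result also allows a reading of the aryl substituent in this series, since 1-phenylethyl in place of 1-(4-acetamidophenyl)ethyl on the amine nitrogen gives a 2.3-fold higher number from compound 3 to compound 4 (0.37 log units; beyond the scatter), and no measurement at hand explains any of these steps.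

The compounds shown leave open how the step to compound 4 divides between the methylene link and the methyl group on the new stereocentre, which a plain benzylaminomethyl group would separate. They also leave open how the opposite enantiomer of the 1-phenylethyl group, or a methoxy group in place of the acetamido group, would read in this assay.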